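A few compounds are considered here, and "the series" means these few. Any claim that something is new, unique, unknown or untested is made for them only; others in the source may bear on it.

In a functional assay on MCF7 cells (Homo sapiens) for cytotoxicity, read by MTT assay, with a stated time of 72 h (on this read-out lower numbers stand for stronger inhibition and higher numbers for weaker inhibition), compound 3 (`O=C(/C=C/c1cc(Br)c(O)c(Br)c1)Nc1cc2c(Nc3ccc(F)c(Cl)c3)ncnc2cc1O[C@H]1CCOC1`) gives 30600 nM and compound 1 (`COc1ccc(/C=C/C(=O)Nc2cc3c(Nc4ccc(F)c(Cl)c4)ncnc3cc2O[C@H]2CCOC2)c(OC)c1`) gives 28600 nM. For the measured compounds named here, these are the only two numbers so far, and they lie within the scatter of each other. Compound 2 (`COc1ccc(/C=C/C(=O)Nc2cc3c(Nc4ccc(F)c(Cl)c4)ncnc3cc2OC)cc1`), which also carries 4-methoxyphenyl, is reported as "not active" (no number reported), without a number. Compound 4 (`COc1ccc(/C=C/C(=O)Nc2cc3c(Nc4ccc(F)c(Cl)c4)ncnc3cc2O[C@H]2CCOC2)cc1`) differs from compound 3 by one change: 4-methoxyphenyl in place of 3,5-dibromo-4-hydroxyphenyl on a double-bonded chain carbon bound to a double-bonded chain carbon. Going by the values given here, the one measured step bearing on this change, a 1.1-fold higher number from compound 1 to compound 3 (0.03 log units; within the scatter), exchanged one substituted phenyl group for another at the same place and stayed within the scatter, so no step beyond the scatter is expected in this assay. The expected step is a 1.0-fold lower number from compound 3 to compound 4 (0.01 log units; within the scatter). For compound 4 the estimated value is 30000 nM, with an expected range of 13000 nM to 70000 nM.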

Compound 4, half-maximal inhibitory concentration: 5070 nM
Estimate against measurement, compound 4: 5.9-fold (0.77 log units) above, outside the stated range (below it).
By their numbers in this assay, from the lowest: compound 4; then compounds 1 and 3 (each within the scatter of the next).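

In this assay, the group on a double-bonded chain carbon bound to a double-bonded chain carbon can shift the number beyond the scatter, which the earlier exchange of one substituted phenyl group for another did not show. Replacing 3,5-dibromo-4-hydroxyphenyl with 4-methoxyphenyl gives a clear drop (a 6.0-fold lower number from compound 3 to compound 4 (0.78 log units; beyond the scatter)), and so does hydrogen in place of methoxy on an aromatic carbon (a 5.6-fold lower number from compound 1 to compound 4 (0.75 log units; beyond the scatter)). Nothing available explains either step.

The compounds shown leave open whether plain phenyl would keep the lower number. They also leave open how a 4-aminophenyl or 4-carboxyphenyl group would read at this place.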